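From compound 1 to compound 3: a hydroxy-ended chain

A few compounds are considered here, and "the series" means these few. Any claim that something is new, unique, unknown or untested is made for them only; others in the source may bear on it.

Measured compounds:
Compound 1 `CCCCSS[C@H]1C[C@H](n2cc(C)c(=O)[nH]c2=O)O[C@@H]1CO` gives < 8 h
Compound 2 `Cc1cn([C@H]2C[C@H](SSCCO)[C@@H](CO)O2)c(=O)[nH]c1=O` gives < 8 h

In a physicochemical assay for metabolic stability, in the presence of a further agent that is not named here (a lower number here means that the compound disappears faster, a higher number that the compound lasts longer), compound 1 stands at < 8 h as a limit and not as a number. Compound 3 `Cc1cn([C@H]2C[C@H](SSCCCCCCO)[C@@H](CO)O2)c(=O)[nH]c1=O` differs from it by 2-hydroxyethyl in place of hydrogen on a saturated chain carbon, four bonds along the chain from a sulfur and, read one bond further out, the same difference is ethyl to 4-hydroxybutyl. Going by the values given here, one measured step bears on this change, namely a step that the two limits leave unreadable from compound 1 to compound 2 with hydroxy in place of ethyl on a saturated chain carbon. Neither its size nor its direction can be read, and the limit of < 8 h in this assay, at which 2 of the 2 values shown sit, is all that the two compounds offer. No step beyond the usual scatter is therefore expected in this assay and another limit would be no surprise. The expected step is a step that the limit leaves unreadable from compound 1 to compound 3 as a rough estimate. Compound 3 is expected to show a half-life of 5 h with an estimated range from 2 h to 9 h in this measurement.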

Compound 3, half-life: < 8 h
Compound 3 gave a limit, no number; the forecaster's own chance of this, stated with the estimate: 65%; the middle value lies beyond the limit too.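

In this assay compound 3 gives < 8 h, which is a limit and not a number. Going by these compounds alone, no step among compound 1, compound 2 and compound 3 can be read: the limit of < 8 h in this assay, at which 3 of the 3 values shown sit. How long each of these compounds actually lasts, and whether their different chains change that, stays open.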